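A few compounds are considered here, and "the series" means these few. Any claim that something is new, unique, unknown or untested is made for them only; others in the source may bear on it.

Measured in a functional assay on MCF7 cells (Homo sapiens) for inhibition, read by MTT assay, with a stated time of 48 h; on this read-out lower numbers stand for stronger inhibition and higher numbers for weaker inhibition:
- Compound 1 `Cc1ccc(/C=C2\SC(=O)N(CC(=O)Nc3c(C)n(C)n(-c4ccccc4)c3=O)C2=O)cc1`: 65500 nM
- Compound 2 `COc1ccc(/C=C2\SC(=O)N(CC(=O)Nc3c(C)n(C)n(-c4ccccc4)c3=O)C2=O)cc1`: 75600 nM
- Compound 3 `Cc1c(NC(=O)CN2C(=O)S/C(=C\c3ccc(Br)cc3)C2=O)c(=O)n(-c2ccccc2)n1C`: 24100 nM

Compound 3 stands lowest of the three in this assay, at 24100 nM. The two measured compounds above it differ little from each other, with a 1.2-fold higher number from compound 1 to compound 2 (0.06 log units; within the scatter). Bromo, by contrast, separates itself modestly from both other groups, with a 2.7-fold lower number from compound 1 to compound 3 (0.43 log units; beyond the scatter) and a 3.1-fold lower number from compound 2 to compound 3 (0.50 log units; beyond the scatter).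

The next compound to be tested is compound 4 `Cc1cc(C)c(/C=C2\SC(=O)N(CC(=O)Nc3c(C)n(C)n(-c4ccccc4)c3=O)C2=O)c(C)c1`. It has 2,4,6-trimethylphenyl in place of 4-bromophenyl on a double-bonded chain carbon bound to a double-bonded ring carbon.

This change gives up the bromo, and the nearest guide is therefore the bromo-for-methyl exchange, a 2.7-fold lower number from compound 1 to compound 3 (0.43 log units; beyond the scatter), read in reverse. The bromo-for-methoxy exchange, a 3.1-fold lower number from compound 2 to compound 3 (0.50 log units; beyond the scatter), points the same way and is of similar size. Among the compounds with values here, no measured compound shows what a ring with several methyl groups does, so this reading carries real uncertainty.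

A modest move back towards the numbers of compound 1 and compound 2 is expected in this assay. The expected change is a 2.3-fold higher number from compound 3 to compound 4 (0.36 log units; beyond the scatter). Compound 4 is estimated at 55000 nM, within an expected range of 25000 nM to 120000 nM.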

Compound 4, half-maximal inhibitory concentration: 71100 nM
Estimate against measurement, compound 4: 1.3-fold (0.11 log units) below, and the stated range covers the measured number.
By their numbers in this assay, from the lowest: compound 3; then compounds 1, 4 and 2 (each within the scatter of the next).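

In this assay, 2,4,6-trimethylphenyl in place of 4-bromophenyl on a double-bonded chain carbon bound to a double-bonded ring carbon gives a 3.0-fold higher number from compound 3 to compound 4 (0.47 log units; beyond the scatter), so a third group at this position now stands apart from the bromo compound. The added methyl groups make no difference that can be read, and neither does the methoxy: the comparisons show a 1.1-fold higher number from compound 1 to compound 4 (0.04 log units; within the scatter) and a 1.1-fold lower number from compound 2 to compound 4 (0.03 log units; within the scatter), which places compounds 1, 2 and 4 together within the scatter, with compound 3 as the only one of the four set apart. No measured evidence on the compounds accounts for this separation.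

All of this rests on a single bromo compound, so the compounds shown leave open whether the lower number belongs to bromo alone or would also appear with chloro, fluoro or iodo on the same ring. They also leave open what an amine or a carboxylic acid on that ring would do, and whether any change to the shared core would alter the picture at this position.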